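This account rests on a few compounds, and the source may have more. Where it says the series, first, only, none or still open, it means among the compounds named here.

Measured in a functional assay on the whole organism (B cells) with Mus musculus as the target; a higher number here means a larger maximal response, a lower number a smaller maximal response:
- compound 1, `C=CCn1c(=O)n(CCCCCCCC)c2nc(N)nc(O)c21`: 130%
- compound 2, `Nc1nc(O)c2c(n1)n(C1OC(CO)[C@@H](O)[C@H]1O)c(=O)n2Cc1ccc(Cl)cc1`: 15%
- compound 3, `C=CCn1c(=O)n(CCCCO)c2nc(N)nc(O)c21`: 12%

Compound 2 sits between the other two, but not evenly: its number and that of compound 3 lie within the usual scatter of each other, while compound 1 stands far higher than compound 2. Going by the values given here, the only single-point step measured so far is the one in which a number 118 percentage points lower from compound 1 to compound 3 (beyond the scatter), a change on a saturated chain that is unrelated to the change considered here.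

Compound 4, `Nc1nc(O)c2c(n1)n(C1OC(CO)[C@@H](O)[C@H]1O)c(=O)n2Cc1ccccc1`, differs from compound 2 by hydrogen in place of chloro on an aromatic carbon. The chloro leaves and only a hydrogen atom enters, at a position para to a large group; no ring, donor or acceptor is added or lost. Among the compounds with values here, no measured step concerns a change of this kind, so the expectation rests on the small size of the change alone: a step of a number 3 percentage points higher from compound 2 to compound 4 (within the scatter) is expected, which is none beyond the scatter. Compound 4 is therefore estimated at 18%, within a range from 8% to 45%.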

Compound 4, largest response reached (reported as maximal response), in percent of the reference or control that the assay uses: 110%
The estimate for compound 4 lay 92 percentage points below the measured number; the measured number lies above the stated range.
By their numbers in this assay, from the lowest: compounds 3 and 2 (each within the scatter of the next); then compound 4; then compound 1.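

Going by these compounds alone, the change from 4-chlorobenzyl to benzyl gives a number 95 percentage points higher from compound 2 to compound 4 (beyond the scatter) in this assay and so places a large step on the aromatic ring, where the only earlier single-place step lay on a saturated chain. This position is therefore far from silent: one chlorine atom on an aromatic carbon, para to a large group, separates a low maximal response from a high one, although no ring, donor or acceptor changes. Nothing available explains how this single atom has so large an effect.

As far as these compounds go, whether any group at this carbon would hold the response down, or chloro alone, stays open; fluoro, bromo, methyl and methoxy would each test this. Also open, from the compounds shown here alone, is whether the same swap would matter as much on a core carrying a different side chain.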